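Hydroxypyrrolidine Amide in a Pyridine Ether Series

The source may report more compounds than this note shows. Statements on the series, on what has been measured and on what is new or still open speak of the compounds shown alone.

The series shares one core, seen in compound 1 `NCc1cc(Oc2cccc(Oc3ccccc3)c2)nc(C(F)(F)F)c1`, and in an ADME assay on the whole organism (plasma, Mus musculus) for pharmacokinetics, read by LC-MS, at a dose of 30 mg/kg by the oral route (a higher number here means more compound in the circulation at the dose given, a lower number less compound in the circulation), compound 1 gives "not determined" (no result reported). Compound 2 `NCc1cc(Oc2cccc(C(=O)N3CC[C@@H](N)C3)c2)nc(C(F)(F)F)c1` gives 670 nM in this assay, and compound 3 `NCc1cc(Oc2cccc(C(=O)Nc3ccccc3)c2)nc(C(F)(F)F)c1` gives 860 nM, the higher of the two numbers, though the step of a 1.3-fold higher number from compound 2 to compound 3 (0.11 log units; within the scatter) lies within the scatter. Compound 4 `NCc1cc(Oc2cccc(C(=O)N3CC[C@@H](O)C3)c2)nc(C(F)(F)F)c1` differs from compound 3 by 3-hydroxypyrrolidin-1-yl in place of anilino on a carbonyl carbon. Within the data shown here, the only step that bears on this, compound 2 to compound 3, is small, so a step in this assay of no more than scatter size is expected, a 1.2-fold lower number from compound 3 to compound 4 (0.09 log units; within the scatter), pointing slightly down toward what compound 2 showed. Compound 4 is therefore estimated at 700 nM, within a range of 250 nM to 2000 nM.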

Compound 4, maximal plasma concentration: 5130 nM
The estimate for compound 4 lay 7.3-fold (0.87 log units) below the measured number; measured number outside the range, above it.
By their numbers in this assay, from the lowest: compounds 2 and 3 (each within the scatter of the next); then compound 4.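

At this carbonyl carbon, the choice of amide group clearly matters in this assay, with a 6.0-fold higher number from compound 3 to compound 4 (0.78 log units; beyond the scatter) beyond the scatter, whereas compound 2 and compound 3 had stayed within it. The substituent on the saturated ring carbon matters too: a 7.7-fold higher number from compound 2 to compound 4 (0.88 log units; beyond the scatter) shows that the pyrrolidine ring alone does not carry the rise, which appears only with hydroxy and not with amino. Nothing measured here accounts for this rise. On these data alone, it remains open whether a methoxy group or a fluorine atom in place of the hydroxy would keep the higher number, and whether the opposite configuration at the stereocentre would do so.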